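The source may report more compounds than this note shows. Statements on the series, on what has been measured and on what is new or still open speak of the compounds shown alone.

In a functional assay on K562 cells (Homo sapiens) for cytotoxicity, read by MTT assay, with a stated time of 24 h (on this read-out higher numbers stand for weaker inhibition and lower numbers for stronger inhibition), compound 1 `COc1cc(/C=C2\CN(C)C/C(=C\c3ccc(Cl)cc3)C2=O)cc(OC)c1` gives 13300 nM, compound 2 `COc1cc(/C=C2\CN(C)C/C(=C\c3ccc(Cl)cc3Cl)C2=O)cc(OC)c1` gives 11900 nM and compound 3 `CN1C/C(=C\c2ccc(F)cc2)C(=O)/C(=C/c2ccc(C#N)cc2)C1` gives 11300 nM. Compound 3 therefore stands level with the other two, all three values lying within the scatter of one another. Compound 4 `CN1C/C(=C\c2ccc(C#N)cc2)C(=O)/C(=C/c2ccc(Cl)cc2Cl)C1` departs from compound 3 by one change: 2,4-dichlorophenyl in place of 4-fluorophenyl on a double-bonded chain carbon bound to a double-bonded ring carbon. Within the data shown here, the only measured step bearing on this is a 1.1-fold lower number from compound 1 to compound 2 (0.05 log units; within the scatter), a chloro in place of hydrogen on an aromatic carbon, and it stays within the scatter. No step beyond the scatter, in either direction, is therefore expected in this assay. The expected step is a 1.1-fold lower number from compound 3 to compound 4 (0.05 log units; within the scatter). Compound 4 is estimated at 10000 nM, with an expected range of 5000 nM to 20000 nM.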

Compound 4, half-maximal inhibitory concentration: 11900 nM
Beside the measured number, compound 4's estimate is 1.2-fold (0.08 log units) below it, within the range that was stated.
By their numbers in this assay, from the lowest: compounds 3, 2, 4 and 1 (each within the scatter of the next).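

In this assay, a 1.1-fold higher number from compound 3 to compound 4 (0.02 log units; within the scatter) stays within the scatter when 2,4-dichlorophenyl replaces 4-fluorophenyl on a double-bonded chain carbon bound to a double-bonded ring carbon. This position thus tolerates exchange of a whole substituted phenyl, not only the added chloro of the earlier pair, in a compound that also carries a nitrile. No measured evidence accounts for these level values. No step shown lies beyond the scatter, so what can shift the number at this position remains open. Whether an amine or a carboxylic acid in place of these phenyl groups would do so is also unresolved.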